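This account rests on a few compounds, and the source may have more. Where it says the series, first, only, none or still open, it means among the compounds named here.

Compound 3 `N#Cc1ccc(-c2cc(-c3ccccc3)cc(-c3ccco3)n2)cc1` is the least soluble of the three compounds measured in a physicochemical assay for solubility, at pH 6; on this read-out lower numbers stand for lower solubility and higher numbers for higher solubility: compound 3 gives 2000 nM. Compound 1 `Cn1ccnc1-c1cc(-c2ccc(C(N)=O)cc2)cc(-c2ccc(C#N)cc2)n1` gives 8000 nM, and compound 2 `Cn1nncc1-c1cc(-c2ccc(C(N)=O)cc2)cc(-c2ccc(C#N)cc2)n1` gives 32000 nM; compound 3 sits a clear distance below both, further from compound 2 than from compound 1.

Compound 4 `N#Cc1ccc(-c2cc(-c3ccc(C(=O)NN)cc3)cc(-c3ccco3)n2)cc1` differs from compound 3 in one place: aminocarbamoyl in place of hydrogen on an aromatic carbon, the new group sitting on an aromatic carbon of a six-membered aromatic ring of carbon only. Among the compounds with values here, the only step recorded so far, a 4.0-fold higher number from compound 1 to compound 2 (0.60 log units; beyond the scatter), concerns an exchange of one five-membered heteroaryl for another and does not touch the phenyl ring in question, so it bears on the present change only loosely. Within the data shown here, compound 1 and compound 2 both carry a carbamoyl on the corresponding ring and both give higher numbers than compound 3, but they also differ from compound 3 elsewhere, so no single step links them. On this thin basis the step from compound 3 to compound 4 in this assay is expected to be a modest rise, a 2.5-fold higher number from compound 3 to compound 4 (0.40 log units; beyond the scatter). For compound 4 the solubility is estimated at 5000 nM, within a range from 1500 nM to 16000 nM.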

Compound 4, solubility: 500000 nM
The estimate for compound 4 lay 100-fold (2.00 log units) below the measured number; the whole stated range lies below it.
By their numbers in this assay, from the lowest: compound 3; then compound 1; then compound 2; then compound 4.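

In this assay, aminocarbamoyl in place of hydrogen, on an aromatic carbon of a six-membered aromatic ring of carbon only and para to a large group, gives a 250-fold higher number from compound 3 to compound 4 (2.40 log units; beyond the scatter). Within the data shown here, the only earlier step, a 4.0-fold higher number from compound 1 to compound 2 (0.60 log units; beyond the scatter), exchanged one five-membered heteroaryl for another and said nothing about this ring, whereas this large step shows that one substituent at this place can move the read-out far on its own. The entering group has no ring and no net charge, and nothing measured here accounts for the size of the step.

From the compounds shown here alone, it remains open how much of the step depends on the terminal amino group of the aminocarbamoyl, a question that a carbamoyl, a carboxylic acid or a simple amine at the same place on compound 3 would help to separate. Among these compounds, it is also open whether a rise of this size would carry over to a compound with the five-membered heteroaryl of compound 1 or compound 2 in place of the one in compound 3.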